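Notes on the step from compound 2 to compound 4

A few compounds are considered here, and "the series" means these few. Any claim that something is new, unique, unknown or untested is made for them only; others in the source may bear on it.

Measured in a functional assay on MCF7 cells (Homo sapiens) for cytotoxicity, read by MTT assay, with a stated time of 48 h; a lower number here means a stronger inhibitor of growth, a higher number a weaker inhibitor of growth:
compound 1 (`Clc1cc2nc(-c3ccccc3Cl)[nH]c2cc1Cl`) gives 22000 nM
compound 2 (`Cn1c(C(F)(F)F)nc2cc(Cl)c(Cl)cc21`) gives 39000 nM
compound 3 (`FC(F)(F)c1cccc(Cn2c(C(F)(F)F)nc3cc(Cl)c(Cl)cc32)c1`) gives 68000 nM

Compound 2 lies within the scatter of compound 1 and also within the scatter of compound 3, so it holds no distinct place among the three numbers. All three are weak growth inhibitors in this assay on these values.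

Compound 4 (`Nc1ccccc1Cn1c(C(F)(F)F)nc2cc(Cl)c(Cl)cc21`) is the next compound to be read. Its difference from compound 2 (2-aminophenyl in place of hydrogen on a saturated chain carbon bound to an aromatic nitrogen) is 2-aminophenyl in place of hydrogen on a saturated chain carbon bound to an aromatic nitrogen. Within the data shown here, no measured pair isolates this change, so the series gives no direct size for it. Compound 3 also carries an aromatic ring on that chain carbon, and compound 3 (68000 nM) stays within the scatter of compound 2 (39000 nM). Among the measured compounds shown here, no measured compound carries an amino group, which leaves the expectation loose. The estimated step (a 1.1-fold lower number from compound 2 to compound 4 (0.05 log units; within the scatter)) stays within the scatter, and no real change in either direction is expected. For compound 4 the estimated value is 35000 nM (expected range 12000 nM to 90000 nM).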

Compound 4, concentration for 50% growth inhibition: 55600 nM
The estimate for compound 4 lay 1.6-fold (0.20 log units) below the measured number; low and high end bracket the measured number.
By their numbers in this assay, from the lowest: compounds 1, 2, 4 and 3 (each within the scatter of the next, the first and the last beyond it).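

In this assay, among these compounds, the change is read directly for the first time at this position: the step is a 1.4-fold higher number from compound 2 to compound 4 (0.15 log units; within the scatter), so 2-aminophenyl in place of hydrogen on a saturated chain carbon bound to an aromatic nitrogen gives no real change in the number. The earlier compounds shown here held no amino group, and compound 4 now shows that a group carrying one can sit at this place, with compound 4 at 55600 nM, without leaving the scatter of compound 2. The result therefore sets no direction for this change, and nothing at hand accounts for the size of the step.

Still open, as far as these compounds go, is whether any group at this place can move the number beyond the scatter of compound 2, for instance a carboxylic acid or a longer alkyl chain in place of 2-aminophenyl. Also open, from the compounds shown here alone, is what the ring and the amino group each contribute to this step, which an unsubstituted phenyl at the same place would begin to separate.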